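Working notes on cytotoxicity across three analogues

The source may hold more compounds than are shown below. What is called first, only, known or untested is meant among the compounds shown, and "the series" means these compounds.

Compound 1 `O=S(=O)(Cc1nc(-c2ccncc2)c2sccc2n1)c1cccc(Cl)c1` was tested in an ADME assay on cells (Homo sapiens) for cytotoxicity, read by resazurin assay, with a stated time of 5 days; a higher number here means that more compound is tolerated, a lower number that less compound is tolerated. In this assay compound 1 gives only a limit, > 50000 nM. Compound 2 `COc1ccc(-c2nc(CSc3cc(C)cc(C)c3)nc3ccsc23)cn1` belongs to the same set. In this assay compound 2 likewise reaches only a limit, > 50000 nM. Where compound 1 stands is therefore fixed from one side only: the limit of > 50000 nM in this assay, at which 2 of the 2 values shown sit, so there is no number to rank it against, and no measured step between any two compounds of the set exists.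

Compound 3 `O=S(=O)(Cc1nc(-c2cccs2)c2sccc2n1)c1cccc(Cl)c1` has not yet been measured. It differs from compound 1 in one place: thiophen-2-yl in place of pyridin-4-yl on an aromatic carbon. Among the compounds with values here, no measured step in this assay is available to calibrate this change, and the two values shown are both limits. The expectation for compound 3 is that the step of a number no higher from compound 1 to compound 3 (the limit leaves the size open) stays within the scatter and that the result again sits at the limit. In this assay compound 3 is estimated at 50000 nM, with a range from 20000 nM to 120000 nM, and most likely it is reported once more only as a limit.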

Compound 3, half-maximal cytotoxic concentration: > 50000 nM
Compound 3 ended at the assay's limit; the forecaster's own chance of this, stated with the estimate: 80%; the middle value lies on the limit itself.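

No step can be read from compound 1 to compound 3 in this assay, as the two results are limits and not numbers: the limit of > 50000 nM in this assay, at which 3 of the 3 values shown sit.

The compounds shown leave open whether thiophen-2-yl and pyridin-4-yl differ at all in this assay, and at what concentration, if any, these compounds become cytotoxic.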